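The source may hold more compounds than are shown below. What is called first, only, known or untested is meant among the compounds shown, and "the series" means these compounds.

Working notes on the series. In a functional assay on HL-60 cells (Homo sapiens) for cytotoxicity, read by WST assay, with a stated time of 48 h (on this read-out lower numbers stand for an effect already at smaller amounts and higher numbers for an effect only at larger amounts of compound), compound 1 `O=C1OC[C@H](Cc2ccccc2)[C@H]1Cc1ccccc1C(F)(F)F` gives 37000 nM, compound 2 `O=C1OC[C@H](Cc2ccccc2)[C@H]1Cc1ccc(Cl)c(Cl)c1` gives 19000 nM and compound 3 `O=C1OC[C@H](Cc2ccccc2O)[C@H]1Cc1ccc(Cl)c(Cl)c1` gives 33000 nM. Compound 3 lies within the scatter of both others. Compound 4 `COc1ccccc1C[C@H]1COC(=O)[C@@H]1Cc1ccc(Cl)c(Cl)c1` differs from compound 3 by methyl in place of hydrogen on an oxygen on an aromatic ring, 2-hydroxyphenyl to 2-methoxyphenyl: methyl in place of hydrogen on an oxygen on an aromatic ring. Within the data shown here, no measured step covers this change directly. The nearest is hydroxy in place of hydrogen on an aromatic carbon, a 1.7-fold higher number from compound 2 to compound 3 (0.24 log units; within the scatter), which stayed within the scatter. On that evidence, no step beyond the scatter is expected in this assay, and the expected step is a 1.2-fold lower number from compound 3 to compound 4 (0.07 log units; within the scatter). The estimate for compound 4 is 28000 nM, with an expected range of 14000 nM to 55000 nM.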

Compound 4, half-maximal effective concentration: 14000 nM
The estimate for compound 4 lay 2.0-fold (0.30 log units) above the measured number; measured number inside the range.
By their numbers in this assay, from the lowest: compounds 4, 2, 3 and 1 (each within the scatter of the next, the first and the last beyond it).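

In this assay, methyl in place of hydrogen on the oxygen gives a step beyond the scatter, a 2.4-fold lower number from compound 3 to compound 4 (0.37 log units; beyond the scatter), so this position responds to a change that the hydroxy step alone did not reveal. Methoxy in place of hydrogen on the aromatic carbon gives a 1.4-fold lower number from compound 2 to compound 4 (0.13 log units; within the scatter), which stays within the scatter, so only the hydroxy-to-methoxy comparison separates these compounds. No evidence on the cause is at hand. Going by these compounds, whether an ethyl group or a longer chain on this oxygen would extend the step remains open, as does the effect of an amine in place of the methoxy.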